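The source may hold more compounds than are shown below. What is called first, only, known or untested is meant among the compounds shown, and "the series" means these compounds.

Working notes on the amide series sharing the core of compound 1 `O=C(Nc1cc(Cl)cc(Cl)c1)c1cnc(Cl)nc1C(F)(F)F`.

Three compounds have been run in an assay on Jurkat cells for inhibition of cyclic AMP-dependent transcription factor ATF-1 (Homo sapiens); a higher number here means a weaker inhibitor, a lower number a stronger inhibitor. Compound 1 gives 500 nM. Compound 2 `Cc1cc(NC(=O)c2cnc(Cl)nc2C(F)(F)F)on1`, which carries a small heteroaromatic amine in place of the dichlorophenyl group, gives 3800 nM in this assay. Compound 3 `O=C(Nc1cc(C(F)(F)F)cc(C(F)(F)F)c1)c1cnc(Cl)nc1C(F)(F)F` gives 50 nM in this assay, the lowest number of the three; its gaps to compound 1 and to compound 2 are both beyond the usual scatter, so compound 3 is the strongest inhibitor seen so far.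

Compound 4 `CCCCCCOC(=O)c1cc(NC(=O)c2cnc(Cl)nc2C(F)(F)F)cc(C(F)(F)F)c1` has not yet been measured. Relative to compound 3 the change is hexyloxycarbonyl in place of trifluoromethyl on an aromatic carbon. Within the data shown here, no pair of measured compounds isolates this kind of change, so the direction is open. Compound 3 at 50 nM is the only anchor. A modest weakening, or no change beyond the scatter, is taken as the expectation for compound 4, giving an estimated step of a 2.4-fold higher number from compound 3 to compound 4 (0.38 log units; beyond the scatter) in this assay. Compound 4 is therefore expected to give about 120 nM in this assay, with a plausible range from 25 nM to 600 nM.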

Compound 4, half-maximal inhibitory concentration: 660 nM
For compound 4 the middle estimate is 5.5-fold (0.74 log units) below the measured one, outside the stated range (above it).
By their numbers in this assay, from the lowest: compound 3; then compounds 1 and 4 (each within the scatter of the next); then compound 2.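

In this assay, among these compounds, hexyloxycarbonyl in place of trifluoromethyl on this aromatic carbon gives a 13-fold higher number from compound 3 to compound 4 (1.12 log units; beyond the scatter) as a large step, the first reading of a change at this position. The position is therefore not indifferent to the group it carries, although the change leaves a measurable inhibitor, with compound 4 at 660 nM in this assay. No measurement shown here accounts for the size of the step.

The compounds shown do not separate the contribution of the hexyl chain from that of the ester carbonyl. On these data alone, a methoxycarbonyl group or a carboxylic acid on this same aromatic carbon would make that comparison, and whether any replacement of trifluoromethyl here can match compound 3 remains open.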